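Swapping Cyclopentyl for Cyclopropylmethyl on a Weak Growth Inhibitor

The compounds below may be only part of what the source reports. "The series", "measured", "known", "first", "only" and "open" are said of these compounds alone.

Within the data shown here, in a functional assay on AGS cells (Homo sapiens) for antiproliferative activity, read by MTT assay, with a stated time of 48 h (on this read-out higher numbers stand for weaker inhibition of growth and lower numbers for stronger inhibition of growth), compound 3 `COc1ccccc1OCCNc1ccc(=O)n(Cc2ccc(OC(F)F)c(OC3CCCC3)c2)n1` gives 23600 nM as the only true number so far. Compound 1 `COc1ccccc1OCCNc1ccc(=O)n(Cc2ccc(OC)c(OC3CCCC3)c2)n1` gives a limit of the assay and no number (> 100000 nM). Compound 2 `COc1ccc(Cn2ncc(NCCOc3ccccc3OC)c(Cl)c2=O)cc1OC` likewise gives only a limit (> 100000 nM). Compound 4 `COc1ccccc1OCCNc1ccc(=O)n(Cc2ccc(OC(F)F)c(OCC3CC3)c2)n1` has cyclopropylmethyl in place of cyclopentyl on an oxygen on an aromatic ring. Among the measured compounds shown here, the one measured step (an at least 4.2-fold lower number from compound 1 to compound 3 (0.62 log units; beyond the scatter)) is difluoromethyl in place of methyl, a group that compound 4 keeps, so it does not speak directly to this swap. The expectation therefore rests on compound 3 and its 23600 nM alone. For the measured compounds named here, no measured step touches this place, so the expected change is none beyond the scatter (a 1.3-fold higher number from compound 3 to compound 4 (0.10 log units; within the scatter)). Compound 4 is expected near 30000 nM with a range from 10000 nM to 90000 nM in this assay.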

Compound 4, concentration for 50% growth inhibition: 24400 nM
Estimate against measurement, compound 4: 1.2-fold (0.09 log units) above; low and high end bracket the measured number.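

Among these compounds, the group on an oxygen on an aromatic ring had no measured step before this one. In this assay the swap gives a 1.0-fold higher number from compound 3 to compound 4 (0.01 log units; within the scatter) and so cyclopentyl and cyclopropylmethyl cannot be told apart here, although the ring goes from five-membered to three-membered. Compound 3 and compound 4 both give true numbers, clear of the limit that holds much of this small set: the limit of > 100000 nM in this assay, at which 2 of the 4 values shown sit.

Going by these compounds, whether another kind of group here, such as an amine or a carboxylic acid, would shift the number remains open. So does whether cyclopropylmethyl would match cyclopentyl with methyl in place of difluoromethyl.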